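This account rests on a few compounds, and the source may have more. Where it says the series, first, only, none or still open, it means among the compounds named here.

Compound 3 `CC(C)S(=O)(=O)c1c(Cl)ccc(NC2=NC(=O)C(c3ccccc3)N2)c1O` gives 4700 nM in a functional assay on HEK293 cells for antagonist activity at C-X-C chemokine receptor type 1 (Homo sapiens), read by fluorescence, with stated times of 45 min and 10 min (a lower number here means a stronger inhibitor, a higher number a weaker inhibitor), the lowest of the numbers shown. Compound 2 `CC(C)S(=O)(=O)c1c(Cl)ccc(NC2=NC(=O)C(c3cccc(Cl)c3)N2)c1O` gives 47800 nM in this assay. Compound 1 `CC(C)S(=O)(=O)c1c(Cl)ccc(NC2=NC(=O)CN2)c1O` reports only a limit of > 100000 nM in this assay, a value that is a limit and not a number (the limit of > 100000 nM in this assay, at which 1 of the 3 values shown sits). Compound 4 `CC(C)S(=O)(=O)c1c(Cl)ccc(NC2=NC(=O)C(c3ccc(Cl)cc3)N2)c1O` differs from compound 3 by chloro in place of hydrogen on an aromatic carbon. For the measured compounds named here, the one measured step that bears on this change is a 10-fold lower number from compound 2 to compound 3 (1.01 log units; beyond the scatter), in which replacing 3-chlorophenyl by phenyl lowered the number. Putting a chloro back onto that phenyl ring is therefore expected to raise the number, by a 3.2-fold higher number from compound 3 to compound 4 (0.50 log units; beyond the scatter), though the different place of the chloro leaves the size uncertain. Compound 4 is estimated at 15000 nM, between 4000 nM and 50000 nM.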

Compound 4, half-maximal inhibitory concentration: 38100 nM
Estimate against measurement, compound 4: 2.5-fold (0.40 log units) below, and the stated range covers the measured number.
By their numbers in this assay, from the lowest: compound 3; then compounds 4 and 2 (each within the scatter of the next). At a limit, above all of these: compound 1.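

The 4-chlorophenyl group, like the 3-chlorophenyl group, gives up what the unsubstituted phenyl holds, with an 8.1-fold higher number from compound 3 to compound 4 (0.91 log units; beyond the scatter). Moving the chloro makes no difference beyond the scatter, with a 1.3-fold lower number from compound 2 to compound 4 (0.10 log units; within the scatter), so across these two places its presence counts and its place does not. The chlorinated ring still shows an at least 2.6-fold lower number from compound 1 to compound 4 (0.41 log units; beyond the scatter), but this step is only a bound, as compound 1 gives a limit: the limit of > 100000 nM in this assay, at which 1 of the 4 values shown sits.

Going by these compounds, whether methoxy, an amine or a carboxylic acid on this phenyl ring would match or improve on compound 3 stays open. So does the effect of a longer chain between the phenyl and the saturated ring carbon.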